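Carboxy gives way to fluoro, with only limits behind

The compounds below may be only part of what the source reports. "The series", "measured", "known", "first", "only" and "open" are said of these compounds alone.

Compound 1 `CCC1=C(C(=O)OCC2CCCCC2)C(c2ccc(O)cc2)NC(=O)N1`, compound 2 `CCC1=C(C(=O)OCC2CCCCC2)C(c2cccc(N)c2)NC(=O)N1` and compound 3 `CCC1=C(C(=O)OCC2CCCCC2)C(c2ccc(C(=O)O)cc2)NC(=O)N1` share one core and differ in a single group. In an ADME assay on CEMx174 cells (Homo sapiens) for cytotoxicity (a lower number here means that less compound is tolerated, a higher number that more compound is tolerated), compound 1 gives > 10000 nM as a limit of the assay, not a number. Compound 2 gives > 10000 nM as a limit too. Compound 3 gives > 10000 nM as a limit as well. Going by the values given here, compound 3 therefore stands with the others, at the limit of > 10000 nM in this assay, at which 3 of the 3 values shown sit, on the numbers so far.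

Compound 4 `CCC1=C(C(=O)OCC2CCCCC2)C(c2ccc(F)cc2)NC(=O)N1` carries fluoro in place of carboxy on an aromatic carbon, para to a large group: fluoro in place of carboxy on an aromatic carbon describes that swap. Among the compounds with values here, three measured steps bear on it, namely a step that the two limits leave unreadable from compound 1 to compound 3 and a step that the two limits leave unreadable from compound 2 to compound 3 and a step that the two limits leave unreadable from compound 1 to compound 2, and none has a readable size. They offer no direction, so no change beyond the scatter is expected. The expected size in this assay is a step that the limit leaves unreadable from compound 3 to compound 4 and remains only an estimate. For compound 4 the estimated value is 13000 nM with an expected range from 5000 nM to 35000 nM and a report as a limit is likely.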

Compound 4, half-maximal cytotoxic concentration: > 10000 nM
Compound 4 gave a limit, no number; the forecaster's own chance of this, stated with the estimate: 75%; the middle value lies beyond the limit too.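

In this assay compound 4 gives > 10000 nM, a limit and not a number, so no step among compound 1, compound 2, compound 3 and compound 4 can be read: the limit of > 10000 nM in this assay, at which 4 of the 4 values shown sit.

The compounds shown leave open whether swapping these groups changes the tolerated concentration at all.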